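A few compounds are considered here, and "the series" means these few. Any claim that something is new, unique, unknown or untested is made for them only; others in the source may bear on it.

Compound 1, `NC1=NC2(CCSCC2)N(OCCCOc2ccc(Cl)c(Cl)c2)C(N)=N1`: 88.4%
Compound 2, `COc1ccc(OCCCON2C(N)=NC(N)=NC23CCOCC3)cc1`: > 90%, a limit of the assay
Compound 3, `NC1=NC2(CCOCC2)N(OCCCOc2ccc(Cl)c(Cl)c2)C(N)=N1`: > 90%, a limit of the assay

Among the measured compounds shown here, in an assay on isolated protein for inhibition of Dihydrofolate reductase (Homo sapiens), read by spectrophotometry, using NADPH, with stated times of 5 s and 6 min, tested at 5 uM (on this read-out higher numbers stand for a stronger effect at the one concentration tested and lower numbers for a weaker effect), compound 1 gives 88.4%, and this is the only plain number among the three measured compounds. Compound 2 reaches > 90%, which is a limit of the assay and not a number. Compound 3 likewise sits at > 90%, again a limit. For the measured compounds named here, two of the three values thus sit at the limit of > 90% in this assay, at which 2 of the 3 values shown sit, and the one measured step at the oxygen on the saturated carbon, a step that the two limits leave unreadable from compound 2 to compound 3, cannot be read, both of its ends being limits. Going by the values given here, compound 1 therefore stands as the only readable point, and no measured step shows how far an exchange of the aryl group on that oxygen moves the read-out.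

Compound 4, `NC1=NC2(CCSCC2)N(OCCCOc2ccccc2Br)C(N)=N1`, differs from compound 1 in one place: 2-bromophenyl in place of 3,4-dichlorophenyl on an oxygen on a saturated carbon. Among the compounds with values here, no measured step with a readable size bears on this exchange. Compound 4 is therefore expected to stay close to compound 1, with the expected step of a number 3.4 percentage points lower from compound 1 to compound 4 (within the scatter) being one of no size beyond the scatter. Compound 4 is estimated to give 85%, within a range from 68% to 90%.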

Compound 4, a percentage reported as inhibition, at one concentration (the size of the read-out at that concentration, not a potency): 88.7%
Beside the measured number, compound 4's estimate is 3.7 percentage points below it, within the range that was stated.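

At the oxygen on a saturated carbon, 2-bromophenyl in place of 3,4-dichlorophenyl gives, in this assay, a number 0.3 percentage points higher from compound 1 to compound 4 (within the scatter). This is the first step among the compounds shown whose size can be read, and it shows that for this one pair, on the core of compound 1, a single bromine on the phenyl ring can stand in for the two chlorines without the read-out leaving the usual scatter. The step is nevertheless a comparison at one concentration, and it gives no potency for either compound, with the read-out of this pair lying close to the point where the assay stops giving numbers: the limit of > 90% in this assay, at which 2 of the 4 values shown sit.

From the compounds shown here alone, whether these two aryl groups would still match at a lower concentration stays open, as does the step from 4-methoxyphenyl to 3,4-dichlorophenyl, which cannot be read. The compounds shown also leave open how the read-out would respond to an amine or a carboxylic acid in place of the aryl group, or to a longer chain on the oxygen.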